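The compounds below may be only part of what the source reports. "The series", "measured", "known", "first", "only" and "open" are said of these compounds alone.

Compound 1, `O=[N+]([O-])c1ccc(Nc2nccc(-c3ccc(F)cc3)n2)cc1`, gives 863 nM in an assay on isolated protein for inhibition of phosphatidylinositol 4,5-bisphosphate 3-kinase catalytic subunit beta isoform (Homo sapiens); a lower number here means a stronger inhibitor, a higher number a weaker inhibitor.
Compound 2, `Clc1ccc(Nc2nccc(-c3ccc(Cl)cc3Cl)n2)c(Cl)c1`, gives 799 nM in this assay.

Of the compounds shown here, two have been measured so far, and they sit close together: the number for compound 1 and the number for compound 2 lie within the usual scatter of each other, so neither can be called stronger or weaker on this evidence. Both share the same core, an aminopyrimidine carrying an anilino group on one side and an aryl ring on the other.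

The next compound, compound 3, `O=[N+]([O-])c1ccc(Nc2nccc(-c3ccc(Cl)cc3Cl)n2)cc1`, keeps the nitroanilino side of compound 1 and changes only the aryl ring: 2,4-dichlorophenyl in place of 4-fluorophenyl on an aromatic carbon. Among the measured compounds shown here, no measured pair shows this exact change on its own. Compound 2 already carries the same 2,4-dichlorophenyl ring and gives 799 nM, which suggests the new ring is at least tolerated. A step of a 1.2-fold lower number from compound 1 to compound 3 (0.09 log units; within the scatter) is therefore expected, which is no more than the scatter. Compound 3 is estimated at 700 nM, with a likely range from 250 nM to 2000 nM.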

Compound 3, half-maximal inhibitory concentration: 938 nM
Compound 3: the middle estimate sits 1.3-fold (0.13 log units) below what was measured; measured number inside the range.
By their numbers in this assay, from the lowest: compounds 2, 1 and 3 (each within the scatter of the next).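

With the rest of the molecule held fixed, placing 2,4-dichlorophenyl in place of 4-fluorophenyl on this aromatic carbon gives a 1.1-fold higher number from compound 1 to compound 3 (0.04 log units; within the scatter) in this assay. Among the compounds shown here, this is the first time the ring swap can be read on its own, and the two compounds cannot be told apart. On this evidence, the position takes either ring equally well when the rest of the molecule is that of compound 1, and nothing at hand accounts for this.

From the compounds shown here alone, both rings tested here are phenyl rings bearing halogens, so it remains open how this position would respond to a plain phenyl ring, or to a ring carrying an amine or a carboxylic acid. Going by these compounds, it is also open whether the same swap would read alike with a different group on the anilino side.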